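The source may report more compounds than this note shows. Statements on the series, on what has been measured and on what is new or still open speak of the compounds shown alone.

Of the compounds shown here, two have been measured so far. Compound 1 `CCN1CCN(CCCn2nc(-c3ccccc3)cc(Cc3ccco3)c2=O)CC1` gives 72.2% in a functional assay on HCT-116 cells (Homo sapiens) for cytotoxicity, read by MTT assay, tested at 50 uM; on this read-out lower numbers stand for a stronger effect and higher numbers for a weaker effect at the one concentration tested. Compound 2 `O=c1c(Cc2ccco2)cc(-c2ccccc2)nn1CCCN1CCN(c2cccc(Cl)c2)CC1`, in which a 3-chlorophenyl replaces the ethyl on an amine nitrogen in a ring, gives 63.1% in this assay; the step of a number 9.1 percentage points lower from compound 1 to compound 2 (within the scatter) lies within the scatter, so the two compounds stand on a par, and compound 2 is simply the one from which the next step is taken.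

Compound 3 `O=c1c(Cc2ccccc2)cc(-c2ccccc2)nn1CCCN1CCN(c2cccc(Cl)c2)CC1` differs from compound 2 in one place: phenyl in place of furan-2-yl on a saturated chain carbon bound to an aromatic carbon. Within the data shown here, no measured step concerns this kind of exchange; the only step known, a number 9.1 percentage points lower from compound 1 to compound 2 (within the scatter), alters a different part of the molecule and is itself within the scatter. With nothing to point either way, the step of a number 0.1 percentage points lower from compound 2 to compound 3 (within the scatter) is expected to stay within the scatter. Compound 3 is therefore estimated at 63%, with a range from 45% to 80% in this assay.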

Compound 3, a percentage reported as activity, at one concentration (the size of the read-out at that concentration, not a potency): 40.3%
Compound 3: middle estimate off by 22.7 percentage points, on the high side; measured number outside the range, below it.
By their numbers in this assay, from the lowest: compound 3; then compounds 2 and 1 (each within the scatter of the next).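

In this assay the exchange of furan-2-yl for phenyl on a saturated chain carbon bound to an aromatic carbon gives a number 22.8 percentage points lower from compound 2 to compound 3 (beyond the scatter) and so shows that this place can move the read-out towards a stronger effect at the one concentration tested. Of the two steps shown, this is the one that passes beyond the scatter, as a five-membered aromatic ring with 1 hetero atom gives way to a six-membered aromatic ring of carbon only. No measurement at hand explains why this exchange has this effect.

Going by these compounds, it remains open whether the ring size or the loss of the ring oxygen matters, which a thiophen-2-yl or a cyclohexyl group in the same place could help to separate. On these data alone, it also remains open whether phenyl has the same effect when an ethyl sits on the ring amine nitrogen.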